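The compounds below may be only part of what the source reports. "The series", "measured", "known", "first", "only" and "open" are said of these compounds alone.

Compound 3 `CSc1nc(N)nc2c1ncn2/C=C1/CC1(CO)CO` shares one core with compound 1 `CCCNc1nc(N)nc2c1ncn2/C=C1/CC1(CO)CO`, compound 2 `CCCSc1nc(N)nc2c1ncn2/C=C1/CC1(CO)CO` and the still unmeasured compound 4 `CNc1nc(N)nc2c1ncn2/C=C1/CC1(CO)CO`. In an ADME assay on MOLT-3 cells (Homo sapiens) for cytotoxicity, with a stated time of 7 days (a higher number here means that more compound is tolerated, a lower number that less compound is tolerated), compound 3 reports only a limit, > 20000 nM. Compound 2 likewise reports only a limit, > 20000 nM. For compound 1 the entry reads "not determined" (no result reported), so no number exists there. Within the data shown here, the single measured step, a step that the two limits leave unreadable from compound 2 to compound 3, puts hydrogen in place of ethyl on a saturated chain carbon bound to a sulfur, and its size cannot be read because both ends sit at the limit of > 20000 nM in this assay, at which 2 of the 3 values shown sit. Compound 4 differs from compound 3 by methylamino in place of methylsulfanyl on an aromatic carbon. Among the measured compounds shown here, no measured step bears on this change, so the writer expects nothing beyond the scatter; the step is estimated at a step that the limit leaves unreadable from compound 3 to compound 4. Compound 4 is expected near 30000 nM, between 10000 nM and 100000 nM, most probably reported again only as a limit.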

Compound 4, half-maximal cytotoxic concentration: > 20000 nM
Compound 4: only a limit was reported; the forecaster's own chance of this, stated with the estimate: 80%; the middle value lies beyond the limit too.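

No step can be read among compound 2, compound 3 and compound 4, since each stops at a limit: the limit of > 20000 nM in this assay, at which 3 of the 4 values shown sit. The compounds shown leave open how far each lies beyond that limit, and so whether methylamino and methylsulfanyl differ here at all.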